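Dropping a Side Chain From the Hydroxamic Acid Series

The source may hold more compounds than are shown below. What is called first, only, known or untested is meant among the compounds shown, and "the series" means these compounds.

Compound 1 `CSC[C@H](NC(=O)c1ccc(C#Cc2ccccc2)cc1)C(=O)NO` and compound 2 `O=C(NC1(C(=O)NO)CCSCC1)c1ccc(C#Cc2ccccc2)cc1` share one core and were both tested in a physicochemical assay for lipophilicity; a higher number here means a more lipophilic compound, a lower number a more polar compound. Among the compounds with values here, compound 1 gives 3 there, the only plain number among the two values shown. For compound 2 the assay reports only a limit, > 3, and not a number. the limit of > 3 in this assay, at which 1 of the 2 values shown sits, marks where that value sits. Compound 3 `O=C(CNC(=O)c1ccc(C#Cc2ccccc2)cc1)NO` has not yet been measured. It differs from compound 1 at one place: hydrogen in place of (methylsulfanyl)methyl on a saturated chain carbon bound to an amide-type nitrogen and a carbonyl carbon. Within the data shown here, no measured pair of compounds in this set differs at a single place, so there is no earlier step to lean on. Still, the step from compound 1 to compound 3 in this assay is expected to be a clear move downward, well beyond the usual scatter, estimated at a number 1.00 log units lower from compound 1 to compound 3 (beyond the scatter). Compound 3 is therefore expected to give roughly 2 in this assay, within a range of 1.5 to 2.6.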

Compound 3, distribution coefficient: 3
The estimate for compound 3 lay 1.00 log units below the measured number, and the stated range ends below it.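

In this assay, putting hydrogen in place of (methylsulfanyl)methyl on a saturated chain carbon bound to an amide-type nitrogen and a carbonyl carbon gives no change at the digits printed from compound 1 to compound 3 (within the scatter). Within the data shown here, this is the first single-place step in the set, so it offers the first direct reading of this position: here the whole side chain, sulfur included, can leave without a shift that this measurement can distinguish from scatter. The reading of compound 2 is a limit and not a number, so it cannot serve as a further point of comparison: the limit of > 3 in this assay, at which 1 of the 3 values shown sits.

As far as these compounds go, whether other groups at this place would read the same stays open, for instance an amine, a carboxylic acid or a longer chain. A single step on the shared core also cannot say how the same change would read on a different core.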